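The compounds below may be only part of what the source reports. "The series", "measured", "known", "first", "only" and "open" are said of these compounds alone.

Working notes on the series. In a functional assay on A549 cells (Homo sapiens) for antiproliferative activity, read by MTT assay, with a stated time of 48 h (on this read-out higher numbers stand for weaker inhibition and lower numbers for stronger inhibition), compound 1 (`Brc1ccc2[nH]c(-c3cn(-c4ccccc4)nc3-c3ccccc3)nc2c1`) gives 1810 nM, compound 2 (`COc1ccc(-c2nn(-c3ccccc3)cc2-c2nc3cc(F)ccc3[nH]2)cc1`) gives 1980 nM and compound 3 (`COc1ccc(-c2nn(-c3ccccc3)cc2-c2nc3cc(Cl)ccc3[nH]2)cc1`) gives 3130 nM, which places compound 3 within the scatter of both others. Compound 4 (`COc1ccc(-c2nn(-c3ccccc3)cc2-c2nc3cc(Br)ccc3[nH]2)cc1`) differs from compound 3 as follows: bromo in place of chloro on an aromatic carbon. Within the data shown here, only one measured step bears on this swap of one halogen for another: a 1.6-fold higher number from compound 2 to compound 3 (0.20 log units; within the scatter), which stays within the scatter. No change beyond the scatter is therefore expected in this assay, and no direction is favoured. The expected move is a 1.2-fold lower number from compound 3 to compound 4 (0.06 log units; within the scatter). For compound 4 the estimated value is 2700 nM, with an expected range of 1300 nM to 5500 nM.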

Compound 4, half-maximal inhibitory concentration: 6370 nM
Compound 4: middle estimate off by 2.4-fold (0.37 log units), on the low side, and the stated range ends below it.
By their numbers in this assay, from the lowest: compounds 1, 2 and 3 (each within the scatter of the next); then compound 4.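

In this assay this position now shows a step beyond the scatter: bromo in place of chloro gives a 2.0-fold higher number from compound 3 to compound 4 (0.31 log units; beyond the scatter), and bromo in place of fluoro gives a 3.2-fold higher number from compound 2 to compound 4 (0.51 log units; beyond the scatter). With bromo held fixed, the methoxy change also moves the number beyond the scatter, with a 3.5-fold higher number from compound 1 to compound 4 (0.55 log units; beyond the scatter). Nothing available explains either step. Open, on these data alone, is whether an amine or a carboxylic acid at this position would give a lower number than bromo. Also open, as far as these compounds go, is whether the methoxy step holds with fluoro or chloro in place of bromo.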